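Removing a Methyl Group in a Weakly Cytotoxic Series

The compounds below may be only part of what the source reports. "The series", "measured", "known", "first", "only" and "open" are said of these compounds alone.

All three measured compounds share a nitro-substituted, chloro-substituted benzamide and were tested in an ADME assay on Raji cells (Homo sapiens) for cytotoxicity, with a stated time of 72 h; on this read-out lower numbers stand for an effect already at smaller amounts and higher numbers for an effect only at larger amounts of compound. Compound 1 `Cc1cc(NC(=O)c2cc([N+](=O)[O-])ccc2Cl)cc(-c2nc3ccccc3s2)c1O` reaches only the limit of the assay, with > 25000 nM, so no number was obtained for it. Compound 2 `Cc1ccc(-c2nc3ccccc3o2)cc1NC(=O)c1cc([N+](=O)[O-])ccc1Cl` likewise gives only a limit, > 14000 nM, which is not a number either. For the measured compounds named here, compound 3 `O=C(Nc1nc(-c2ccc(F)c(F)c2)cs1)c1cc([N+](=O)[O-])ccc1Cl` is the one compound with an actual reading; in this assay compound 3 gives 13000 nM. Compound 2 therefore stands among values that all sit at the weak end of the measured range, and one further value shown is also a limit.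

Compound 4 `O=C(Nc1cccc(-c2nc3ccccc3o2)c1)c1cc([N+](=O)[O-])ccc1Cl` has not yet been measured. It differs from compound 2 in a single place: hydrogen in place of methyl on an aromatic carbon. Methyl leaves and hydrogen enters, on an aromatic carbon of a six-membered aromatic ring of carbon only.

Going by the values given here, no pair of measured compounds differs in exactly one place, so there is no measured step to lean on. Given that a small group is removed, the step from compound 2 to compound 4 is expected to be no larger than the usual scatter, a step that the limit leaves unreadable from compound 2 to compound 4. Compound 4 is thus estimated to read 20000 nM, within a range from 8000 nM to 50000 nM, and it may well return only a limit again.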

Compound 4, half-maximal effective concentration: > 25000 nM
Compound 4: a limit, no number; the forecaster's own chance of this, stated with the estimate: 60%; middle value at least 1.2-fold (0.09 log units) away from the limit.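

In this assay compound 2 and compound 4 each return only a limit of the assay and not a number, so the step between them cannot be read. The compounds shown leave open whether hydrogen in place of methyl on an aromatic carbon changes this cytotoxicity reading at all, and by how much.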